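This account rests on a few compounds, and the source may have more. Where it says the series, first, only, none or still open, it means among the compounds named here.

Compound 1 `O=C(O)CCCc1ccc(NCc2cccc(Oc3ccccc3)c2)cc1` is examined in a functional assay on CHO cells for agonist activity at Free fatty acid receptor 1 (Homo sapiens) (a lower number here means that less compound is needed, a higher number that more compound is needed for the effect), where compound 1 gives 1120 nM. Compound 2 `Cc1nc(-c2ccc(C(F)(F)F)cc2)sc1CNc1ccc(CC(C)C(=O)O)cc1` gives 355 nM in this assay. Of these two numbers, compound 1 holds the higher one, and its gap to compound 2 lies beyond the scatter of repeated measurements. Compound 3 `O=C(O)[C@@H]1C[C@H]1c1ccc(NCc2cccc(Oc3ccccc3)c2)cc1` has not yet been measured in this assay. It differs from compound 1 in one place: 2-carboxycyclopropyl in place of 3-carboxypropyl on an aromatic carbon. The acid that leaves sits at the end of an open chain, whereas the acid that enters sits on a three-membered ring of carbon only, with two defined stereocentres. Among the compounds with values here, no measured pair shows this change, so its effect cannot be read from the data and can only be estimated. For compound 3 a step of a 2.5-fold lower number from compound 1 to compound 3 (0.40 log units; beyond the scatter) is expected, a modest fall beyond the scatter. Compound 3 is estimated to give 450 nM in this assay, with a range from 120 nM to 1700 nM.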

Compound 3, half-maximal effective concentration: 562 nM
Compound 3: the middle estimate sits 1.2-fold (0.10 log units) below what was measured; low and high end bracket the measured number.
By their numbers in this assay, from the lowest: compounds 2, 3 and 1 (each within the scatter of the next, the first and the last beyond it).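

In this assay, the first change seen at this position, on an aromatic carbon para to a large group, gives a 2.0-fold lower number from compound 1 to compound 3 (0.30 log units; within the scatter), so the step from 3-carboxypropyl to 2-carboxycyclopropyl cannot be told apart from repeat-measurement noise. The acid therefore need not sit at the end of an open chain: carried on a three-membered ring of carbon with two defined stereocentres, it still leaves compound 3 in the same range as compound 1. No data at hand offer an explanation for this outcome.

The compounds shown leave open how the other stereoisomers of the 2-carboxycyclopropyl group would read, and whether a cyclobutane ring or a longer chain carrying the carboxylic acid would fit this position equally well. They also leave open whether the same exchange would hold on the core of compound 2.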